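Shortening the alkyl chain on a trimethoxystyryl amide series

A few compounds are considered here, and "the series" means these few. Any claim that something is new, unique, unknown or untested is made for them only; others in the source may bear on it.

Measured compounds:
compound 1 `CCC/C(=C\c1cc(OC)c(OC)c(OC)c1)C(=O)N1CCC=C(Br)C1=O`, 2360 nM
compound 2 `CC/C(=C\c1cc(OC)c(OC)c(OC)c1)C(=O)N1CCC=CC1=O`, 23700 nM
compound 3 `CCCC/C(=C\c1cc(OC)c(OC)c(OC)c1)C(=O)N1CCC=C(Br)C1=O`, 2440 nM

In a functional assay on MDA-MB-231 cells (Homo sapiens) for cytotoxicity, read by MTT assay, with a stated time of 72 h (a higher number here means a weaker inhibitor, a lower number a stronger inhibitor), compound 2 gives the highest number of the three. The difference between the core of compound 2 and the core of compound 3 is not broken down here. Compound 1 and compound 3 differ by hydrogen in place of methyl on a saturated chain carbon, three bonds along the chain from a double-bonded chain carbon, and that step, a 1.0-fold lower number from compound 3 to compound 1 (0.01 log units; within the scatter), is flat. Compound 4 `COc1cc(/C=C(\C)C(=O)N2CCC=CC2=O)cc(OC)c1OC` is the unmeasured analogue of compound 2, differing by hydrogen in place of methyl on a saturated chain carbon bound to a double-bonded chain carbon; this is the same kind of change as from compound 3 to compound 1 but not the same, since the place lies on a saturated chain carbon bound to a double-bonded chain carbon rather than three bonds along the chain. Resting on the flat step a 1.0-fold lower number from compound 3 to compound 1 (0.01 log units; within the scatter), compound 4 is expected to move by a 1.1-fold higher number from compound 2 to compound 4 (0.02 log units; within the scatter). The estimate for compound 4 is 25000 nM, between 8000 nM and 80000 nM.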

Compound 4, half-maximal inhibitory concentration: 11700 nM
Compound 4: the middle estimate sits 2.1-fold (0.33 log units) above what was measured; the measured number falls inside the stated range.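

In this assay, hydrogen in place of methyl on a saturated chain carbon bound to a double-bonded chain carbon gives a 2.0-fold lower number from compound 2 to compound 4 (0.31 log units; beyond the scatter), whereas the same kind of change on the other core gives a flat step. Set side by side, the two steps cannot be told apart: the same change on two cores in this assay, a 1.0-fold lower number (0.01 log units; within the scatter) from compound 3 to compound 1 and a 2.0-fold lower number (0.31 log units; beyond the scatter) from compound 2 to compound 4, 2.0-fold (0.29 log units) apart, within the scatter of two such steps. This fits a change that carries between these two cores, but two pairs, with the change at different places on the chain, do not show that its size is the same on both or that it would hold on any other core.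

On these data alone, it remains open how a longer chain would read on either core. As far as these compounds go, it is also open whether an amine or a carboxylic acid at the chain end would fit alongside these simple alkyl chains.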